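Substituent swap on the aromatic nitrogen of the shared core

The source may hold more compounds than are shown below. What is called first, only, known or untested is meant among the compounds shown, and "the series" means these compounds.

Compound 3 `N#Cc1ccc(Cn2cc(/C=C/C(=O)CC(=O)C(=O)O)c3ccccc32)cc1` stands lowest of the three numbers in an assay on isolated protein for inhibition of DNA nucleotidylexotransferase (Homo sapiens), read by scintillation counting, with a stated time of 10 min (a lower number here means a stronger inhibitor, a higher number a weaker inhibitor), giving 1.4 uM. Compound 2 `C=C(C)Cn1cc(/C=C/C(=O)CC(=O)C(=O)O)c2ccccc21` gives 2.5 uM, and the gap a 1.8-fold lower number from compound 2 to compound 3 (0.25 log units; within the scatter) stays within the scatter. Compound 1 `CC(C)CCn1cc(/C=C/C(=O)CC(=O)C(=O)O)c2ccccc21` gives 16.3 uM, and a 12-fold lower number from compound 1 to compound 3 (1.07 log units; beyond the scatter) is clearly beyond it. Compound 4 `CN(C)C(=O)Cn1cc(/C=C/C(=O)CC(=O)C(=O)O)c2ccccc21` differs from compound 3 only in dimethylcarbamoyl in place of 4-cyanophenyl on a saturated chain carbon bound to an aromatic nitrogen. For the measured compounds named here, the steps that bear on this position, a 6.5-fold lower number from compound 1 to compound 2 (0.81 log units; beyond the scatter) and a 12-fold lower number from compound 1 to compound 3 (1.07 log units; beyond the scatter), show that the group here moves this assay by a modest to large amount, and the two non-aromatic groups both read higher than the 4-cyanophenyl. Going by the values given here, no measured step covers an amide at this carbon. A step of the size a 3.6-fold higher number from compound 3 to compound 4 (0.55 log units; beyond the scatter) toward a higher number is therefore expected. Compound 4 is estimated at 5 uM, between 1.5 uM and 16 uM.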

Compound 4, concentration for 50% inhibition: 8.9 uM
Estimate against measurement, compound 4: 1.8-fold (0.25 log units) below; low and high end bracket the measured number.
By their numbers in this assay, from the lowest: compounds 3 and 2 (each within the scatter of the next); then compounds 4 and 1 (each within the scatter of the next).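

In this assay dimethylcarbamoyl on this carbon does not hold the level of the aromatic group: a 6.4-fold higher number from compound 3 to compound 4 (0.80 log units; beyond the scatter) is a modest step upward. The non-aromatic 1-methylethenyl also reads lower, with a 3.6-fold higher number from compound 2 to compound 4 (0.55 log units; beyond the scatter) as the step, while a 1.8-fold lower number from compound 1 to compound 4 (0.26 log units; within the scatter) leaves dimethylcarbamoyl and isobutyl within the scatter of each other. Nothing measured on these compounds accounts for these steps. Going by these compounds, whether an unsubstituted phenyl reads like 4-cyanophenyl remains open, as does the reading of an amine or a carboxylic acid on this carbon.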